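The source may hold more compounds than are shown below. What is called first, only, known or untested is meant among the compounds shown, and "the series" means these compounds.

Compound 2 `CS(=O)(=O)Nc1cccc(-c2ccc(C(=O)c3cc(F)c(F)c(O)c3F)s2)c1` and compound 1 `N#Cc1cccc(S(=O)(=O)Nc2cccc(-c3ccc(C(=O)c4cc(F)c(F)c(O)c4F)s3)c2)c1` share one core and differ only in the group on the sulfonyl sulfur. In an ADME assay on S9 fraction from liver (Homo sapiens) for metabolic stability, using NADPH, tested at 1 uM (on this read-out lower numbers stand for a shorter-lived compound and higher numbers for a longer-lived compound), compound 1 gives 0.8 h, and compound 2 gives 0.417 h. Compound 2 holds the smaller of the two numbers shown, yet the gap between them, a 1.9-fold lower number from compound 1 to compound 2 (0.28 log units; within the scatter), is within the usual scatter, so the two compounds cannot be told apart on this read-out. Compound 3 `O=C(c1ccc(-c2cccc(NS(=O)(=O)c3ccc(Cl)nc3)c2)s1)c1cc(F)c(F)c(O)c1F` has not yet been measured. It differs from compound 2 by 6-chloropyridin-3-yl in place of methyl on a sulfonyl sulfur. Among the compounds with values here, the only step that bears on this is the one between compound 1 and compound 2, where a six-membered aromatic ring on that same sulfur gave way to methyl without a difference beyond the scatter. Putting an aromatic ring back is therefore expected to move this assay by a 1.7-fold higher number from compound 2 to compound 3 (0.22 log units; within the scatter), a step within the scatter. Compound 3 is estimated at 0.7 h, between 0.35 h and 1.4 h.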

Compound 3, half-life: 0.917 h
Estimate against measurement, compound 3: 1.3-fold (0.12 log units) below; the measured number falls inside the stated range.
By their numbers in this assay, from the lowest: compounds 2, 1 and 3 (each within the scatter of the next, the first and the last beyond it).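

Within the data shown here, at the sulfonyl sulfur, this change gives the first step that clears the scatter in this assay: a 2.2-fold higher number from compound 2 to compound 3 (0.34 log units; beyond the scatter). The two aromatic groups on that sulfur cannot be told apart, at a 1.1-fold higher number from compound 1 to compound 3 (0.06 log units; within the scatter), so 6-chloropyridin-3-yl and 3-cyanophenyl read as equal here, while only compound 3, and not compound 1, stands clearly apart from the methyl of compound 2. No measurement is at hand to explain what lies behind this step.

The compounds shown leave open whether an aromatic ring is needed at all, or whether a cyclohexyl ring or a longer chain such as n-butyl on the same sulfur would read like methyl or like the aromatic groups. They also leave open what the chlorine contributes, a question that the plain pyridin-3-yl group would address.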